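The source may hold more compounds than are shown below. What is called first, only, known or untested is meant among the compounds shown, and "the series" means these compounds.

Compounds measured so far:
compound 1 `O=C(c1cccc(Cl)c1)N1CCC(NS(=O)(=O)c2cc(S(=O)(=O)c3ccccc3)ccc2C(F)(F)F)CC1` — 870 nM
compound 2 `O=C(c1cccnc1)N1CCC(NS(=O)(=O)c2cc(S(=O)(=O)c3ccccc3)ccc2C(F)(F)F)CC1` — 120 nM
compound 3 `O=C(O)c1cccc(S(=O)(=O)N2CCC(NS(=O)(=O)c3cc(S(=O)(=O)c4ccccc4)ccc3C(F)(F)F)CC2)c1` — 190 nM

In an assay on U2OS cells for inhibition of secreted frizzled-related protein 1 (Homo sapiens), read by a luciferase reporter, with a stated time of 18 h (a lower number here means that less compound is needed, a higher number that more compound is needed for the effect), compound 1 gives the highest of the three numbers; the nearest is compound 3 and the furthest compound 2. The next compound is compound 4 `O=C(O)c1ccc(S(=O)(=O)N2CCC(NS(=O)(=O)c3cc(S(=O)(=O)c4ccccc4)ccc3C(F)(F)F)CC2)cc1`, not yet measured in this assay. Relative to compound 1 the change is (4-carboxyphenyl)sulfonyl in place of (3-chlorophenyl)carbonyl on an amine nitrogen in a ring.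

Two measured steps leave from compound 1. Replacing the (3-chlorophenyl)carbonyl group with (3-carboxyphenyl)sulfonyl gave a 4.6-fold lower number from compound 1 to compound 3 (0.66 log units; beyond the scatter), and replacing 3-chlorophenyl with pyridin-3-yl gave a 7.3-fold lower number from compound 1 to compound 2 (0.86 log units; beyond the scatter). Between compound 2 and compound 3 the step of a 1.6-fold higher number from compound 2 to compound 3 (0.20 log units; within the scatter) is small. The step to compound 4 matches the step to compound 3 except for where the carboxylic acid sits on the phenyl ring, and nothing measured here speaks to that point.

The expectation for compound 4 is therefore a lower number than compound 1 of a size comparable to the step to compound 3, with a wider range to allow for the unsampled placement: estimated a 4.0-fold lower number from compound 1 to compound 4 (0.60 log units; beyond the scatter), giving an expected value of 220 nM with a range of 80 nM to 650 nM.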

Compound 4, half-maximal effective concentration: 110 nM
The estimate for compound 4 lay 2.0-fold (0.30 log units) above the measured number; measured number inside the range.
By their numbers in this assay, from the lowest: compounds 4, 2 and 3 (each within the scatter of the next); then compound 1.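

In this assay, among these compounds, the placement of the carboxylic acid on the phenyl ring, the one point the earlier compounds did not address, gives a 1.7-fold lower number from compound 3 to compound 4 (0.24 log units; within the scatter), so the 3-carboxyphenyl and 4-carboxyphenyl groups on the sulfonyl sulfur are not told apart. The (4-carboxyphenyl)sulfonyl group on the amine nitrogen in a ring gives a 7.9-fold lower number from compound 1 to compound 4 (0.90 log units; beyond the scatter) and, against the (pyridin-3-yl)carbonyl group, a 1.1-fold lower number from compound 2 to compound 4 (0.04 log units; within the scatter), so these two replacements for the (3-chlorophenyl)carbonyl group are also not told apart. No evidence bearing on this result is available.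

Going by these compounds, the sulfonyl and the carboxylic acid enter together in compound 3 and compound 4, so their separate shares stay open; a (4-carboxyphenyl)carbonyl group or an unsubstituted phenylsulfonyl group would divide them. Also open, on these data alone, is whether a methyl ester or a primary amide can stand in place of the carboxylic acid.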